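The compounds below may be only part of what the source reports. "The series", "measured", "known", "first", "only" and "open" are said of these compounds alone.

Measured compounds in a functional assay on CHO cells for antagonist activity at prostaglandin E2 receptor EP3 subtype (Homo sapiens), read by cAMP accumulation; a higher number here means a weaker inhibitor, a lower number a stronger inhibitor:
compound 1 `CC(C)C(c1ncco1)c1ccc(-c2ccc3cccc(F)c3c2)[nH]c1=O` — 64 nM
compound 2 `CC(C)C(c1ccc(-c2ccc3cccc(F)c3c2)[nH]c1=O)N1CCN/C1=N\C#N` — 38 nM
compound 3 `Cc1nc(C(c2ccc(-c3ccc4cccc(F)c4c3)[nH]c2=O)C(C)C)[nH]c1C` — 50 nM

All three share the core of compound 1 and differ only in the group on a saturated chain carbon bound to an aromatic carbon and a saturated chain carbon. Compound 1 gives the highest of the three numbers, yet both others sit within the scatter of it: a 1.7-fold lower number from compound 1 to compound 2 (0.23 log units; within the scatter) and a 1.3-fold lower number from compound 1 to compound 3 (0.11 log units; within the scatter). Nothing here separates the three.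

Compound 4 `CC(C)NC(=O)CC(c1ccc(-c2ccc3cccc(F)c3c2)[nH]c1=O)C(C)C` is not yet measured. Against compound 1 the change is (isopropylcarbamoyl)methyl in place of 1,3-oxazol-2-yl on a saturated chain carbon bound to an aromatic carbon and a saturated chain carbon. The two measured steps at this place bear on it directly; both stayed within the scatter, so no step beyond the scatter is expected here either. Compound 4 is therefore expected near compound 1 in this assay, at about 60 nM, with a range from 25 nM to 150 nM. The step of a 1.1-fold lower number from compound 1 to compound 4 (0.03 log units; within the scatter) is the estimated outcome.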

Compound 4, half-maximal inhibitory concentration: 15 nM
Beside the measured number, compound 4's estimate is 4.0-fold (0.60 log units) above it, and the stated range ends above it.
By their numbers in this assay, from the lowest: compound 4; then compounds 2, 3 and 1 (each within the scatter of the next).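

This position is not flat: with (isopropylcarbamoyl)methyl there is a 4.3-fold lower number from compound 1 to compound 4 (0.63 log units; beyond the scatter) and also a 3.3-fold lower number from compound 3 to compound 4 (0.52 log units; beyond the scatter) and a 2.5-fold lower number from compound 2 to compound 4 (0.40 log units; beyond the scatter), while the three groups carrying a five-membered ring stay within the scatter of one another. Within the data shown here, the only steps beyond the scatter at this place therefore come with the one group that has no ring. No measurement here accounts for the gain.

From the compounds shown here alone, whether the amide hydrogen or the isopropyl group carries the gain remains open. A tertiary amide or a carboxylic acid on the same chain would test this.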